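Compound 3 in the sulfonamide series: expected growth inhibition

The source may report more compounds than this note shows. Statements on the series, on what has been measured and on what is new or still open speak of the compounds shown alone.

Measured in a functional assay on cells (leukaemia cell line, Homo sapiens) for inhibition, read by sulforhodamine B assay, with a stated time of 48 h; a higher number here means a weaker inhibitor of growth, a lower number a stronger inhibitor of growth:
compound 1 `O=S(=O)(Nc1ccc(Cl)cc1Cl)c1ccc(-c2cnc(C3CC3)o2)cc1`: 481 nM
compound 2 `COc1cc(NS(=O)(=O)c2ccc(-c3cnc(C4CC4)o3)cc2)ccc1F`: 328 nM

Within the data shown here, compound 2, at 328 nM, cannot be separated from the only other measured compound. Among the measured compounds shown here, the sole measured step is a 1.5-fold lower number from compound 1 to compound 2 (0.17 log units; within the scatter). Compound 3 `Cc1cc(Cl)cc(NS(=O)(=O)c2ccc(-c3cnc(C4CC4)o3)cc2)c1` is not yet measured and differs on a sulfonamide nitrogen: 3-chloro-5-methylphenyl in place of 4-fluoro-3-methoxyphenyl on a sulfonamide nitrogen. The measured step changed the group at that same place and stayed within the scatter, so no step beyond the scatter is expected in this assay, in either direction. One step is thin evidence. The expected step is a 1.2-fold higher number from compound 2 to compound 3 (0.06 log units; within the scatter). The estimate for compound 3 is 380 nM, with an expected range of 150 nM to 1000 nM.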

Compound 3, concentration for 50% growth inhibition: 175 nM
For compound 3 the middle estimate is 2.2-fold (0.34 log units) above the measured one; the range from low to high includes it.
By their numbers in this assay, from the lowest: compounds 3, 2 and 1 (each within the scatter of the next, the first and the last beyond it).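

Position notes: on a sulfonamide nitrogen, the series now has its first step beyond the scatter in this assay, with a 2.7-fold lower number from compound 1 to compound 3 (0.44 log units; beyond the scatter) as 3-chloro-5-methylphenyl replaces 2,4-dichlorophenyl. The replacement of 4-fluoro-3-methoxyphenyl, with its hydrogen-bond acceptor, by 3-chloro-5-methylphenyl, which has none, gives a 1.9-fold lower number from compound 2 to compound 3 (0.27 log units; within the scatter) and so does not separate the two groups. No measurement here bears on the reason for either step.

Still open, going by these compounds, is how an amine or a carboxylic acid on the phenyl ring at this nitrogen would read in this assay. A longer chain in place of the phenyl ring also remains untested in the compounds shown.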